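The compounds below may be only part of what the source reports. "The series", "measured", "known", "first", "only" and "open" are said of these compounds alone.

Two of the measured compounds share one core. Compound 2 `Cc1nc2ccccc2c(=O)n1NS(=O)(=O)c1ccccc1` in a functional assay on the whole organism (strain Sprague-Dawley) for inhibition, with Rattus norvegicus as the target, read by paw edema, with stated times of 30 min and 3 h, at a dose of 80 mg/kg by the oral route (on this read-out higher numbers stand for more inhibition at the one dose given (going by the name of the read-out) and lower numbers for less inhibition), gives 47.8%. Compound 1 `O=c1c2ccccc2nc(CO[N+](=O)[O-])n1NS(=O)(=O)c1ccccc1` differs from it by nitrooxy in place of hydrogen on a saturated chain carbon bound to an aromatic carbon; in this assay compound 1 gives 34%, and the step from one to the other is a number 13.8 percentage points lower from compound 2 to compound 1 (beyond the scatter). Compound 3 `Cc1nc2ccccc2c(=O)n1NC(=O)NC(C)(C)C` has a different core; the difference between the two cores is not broken down here. In this assay compound 3 gives 51%, within the scatter of compound 2 and beyond the scatter against compound 1. Compound 4 `CC(C)(C)NC(=O)Nn1c(CO[N+](=O)[O-])nc2ccccc2c1=O`, not yet measured, differs from compound 3 by nitrooxy in place of hydrogen on a saturated chain carbon bound to an aromatic carbon, the same change in the same place as that made from compound 2 to compound 1. Because that earlier step read a number 13.8 percentage points lower from compound 2 to compound 1 (beyond the scatter), a loss of similar size is expected here, a number 14 percentage points lower from compound 3 to compound 4 (beyond the scatter). Compound 4 is therefore estimated at 37%, expected to fall between 25% and 50%.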

Compound 4, a percentage reported as inhibition, in the whole organism at one dose (the size of the read-out at that dose, not a potency): 43.7%
Compound 4: middle estimate off by 6.7 percentage points, on the low side; the measured number falls inside the stated range.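

In this assay, the new step reads a number 7.3 percentage points lower from compound 3 to compound 4 (within the scatter). Nitrooxy in place of hydrogen on a saturated chain carbon bound to an aromatic carbon carries from one core to the other without a difference that can be told apart: the same change on two cores in this assay, a number 13.8 percentage points lower (beyond the scatter) from compound 2 to compound 1 and a number 7.3 percentage points lower (within the scatter) from compound 3 to compound 4, 6.5 percentage points apart, within the scatter of two such steps. This shows agreement between two pairs at one dose and one read-out; it does not show that the change lowers the number on every core, and on the core of compound 3 the step itself stays within the scatter.

The compounds shown leave open how an amine or a carboxylic acid in place of nitrooxy would read. They also leave open whether a longer chain carrying nitrooxy would behave in the same way on these two cores.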